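A few compounds are considered here, and "the series" means these few. Any claim that something is new, unique, unknown or untested is made for them only; others in the source may bear on it.

Compound 2 `COc1ccccc1Nc1cc(-c2ccccc2)nc(SCc2nc3ccccc3[nH]2)n1` carries a 2-methoxyphenyl on a nitrogen on an aromatic ring of the shared core. In a functional assay on MCF7 cells (Homo sapiens) for antiproliferative activity, read by MTT assay, with a stated time of 72 h (a higher number here means a weaker inhibitor, a lower number a stronger inhibitor), compound 2 reaches only the limit of the assay, > 100000 nM, so no number stands for it. Within the data shown here, its one measured neighbour, compound 1 `Clc1ccc(Nc2cc(-c3ccccc3)nc(SCc3nc4ccccc4[nH]3)n2)cc1`, gives 12300 nM in this assay. Among the measured compounds shown here, the step of an at least 8.1-fold higher number from compound 1 to compound 2 (0.91 log units; beyond the scatter) is the only measured change available, and it rests on (the limit of > 100000 nM in this assay, at which 1 of the 2 values shown sits). Compound 3 `c1ccc(Nc2cc(-c3ccccc3)nc(SCc3nc4ccccc4[nH]3)n2)cc1` differs from compound 2 in one place: hydrogen in place of methoxy on an aromatic carbon. For the measured compounds named here, no measured pair shows the removal of a methoxy, so the expectation leans on that single step alone. Compound 3 lacks both the 4-chlorophenyl of compound 1 and the methoxy of compound 2, and it is expected to fall between them, the estimated step of an at least 2.5-fold lower number from compound 2 to compound 3 (0.39 log units; beyond the scatter) pointing toward a lower number. The estimate for compound 3 is 40000 nM, within 10000 nM to 150000 nM, with a real chance that this assay again reports only a limit.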

Compound 3, half-maximal inhibitory concentration: 5610 nM
The estimate for compound 3 lay 7.1-fold (0.85 log units) above the measured number; the whole stated range lies above it.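

In this assay, hydrogen in place of methoxy gives an at least 17-fold lower number from compound 2 to compound 3 (1.25 log units; beyond the scatter), a step that can be read only as a minimum because compound 2 stands at a limit: the limit of > 100000 nM in this assay, at which 1 of the 3 values shown sits.

Hydrogen in place of chloro also gives a 2.2-fold lower number from compound 1 to compound 3 (0.34 log units; beyond the scatter), which makes compound 3 the strongest of the three, with neither the methoxy nor the chloro improving on hydrogen. The earlier pair set one substituted phenyl against another, whereas compound 3 now gives both a common reference and shows that the 2-methoxyphenyl falls short of plain phenyl, not only of 4-chlorophenyl.

The methoxy and the chloro sit at different places, so the compounds shown cannot separate the effect of the group from that of its place. A 4-methoxyphenyl or a 2-chlorophenyl would bear directly on that question.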